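Aryl hydrazone variation on the shared core

A few compounds are considered here, and "the series" means these few. Any claim that something is new, unique, unknown or untested is made for them only; others in the source may bear on it.

The series shares one core, varied only at the aryl group on a carbon with a double bond to nitrogen. Compound 1 `CN(C)CCn1cnnc1-c1cc(Oc2ccc(NC(=O)N/N=C/c3ccc(Cl)cc3Cl)cc2F)ccn1` carries a 2,4-dichlorophenyl there and compound 2 `CN(C)CCn1cnnc1-c1cc(Oc2ccc(NC(=O)N/N=C/c3c(Cl)cccc3Cl)cc2F)ccn1` a 2,6-dichlorophenyl. In a functional assay on HT-29 cells (Homo sapiens) for cytotoxicity, read by MTT assay, with a stated time of 72 h (a higher number here means a weaker inhibitor, a lower number a stronger inhibitor), compound 1 gives 390 nM. In this assay compound 2 gives 280 nM. The step of a 1.4-fold lower number from compound 1 to compound 2 (0.14 log units; within the scatter) stays within the scatter, so compound 2 and compound 1 cannot be told apart on these two numbers, and compound 2 has no other measured neighbour.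

Compound 3 `CN(C)CCn1cnnc1-c1cc(Oc2ccc(NC(=O)N/N=C/c3c[nH]c4ccccc34)cc2F)ccn1` is the next member. The change is 1H-indol-3-yl in place of 2,6-dichlorophenyl on a carbon with a double bond to nitrogen. Among the measured compounds shown here, the only measured step, a 1.4-fold lower number from compound 1 to compound 2 (0.14 log units; within the scatter), exchanges one dichlorophenyl for another dichlorophenyl and was small. For the measured compounds named here, no measured step replaces that ring with a different ring system, so nothing recorded bears directly on this change. The expected step of a 1.4-fold higher number from compound 2 to compound 3 (0.15 log units; within the scatter) is therefore set close to none beyond the scatter, with a wide range to cover the unknown. Compound 3 is expected to give 400 nM in this assay, with a range from 120 nM to 1500 nM.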

Compound 3, half-maximal inhibitory concentration: 1300 nM
For compound 3 the middle estimate is 3.3-fold (0.51 log units) below the measured one, within the range that was stated.
By their numbers in this assay, from the lowest: compounds 2 and 1 (each within the scatter of the next); then compound 3.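

Among the compounds shown here, the 1H-indol-3-yl is the first replacement on this carbon with a double bond to nitrogen to move the number beyond the scatter in this assay: the comparison gives a 4.6-fold higher number from compound 2 to compound 3 (0.67 log units; beyond the scatter) and also a 3.3-fold higher number from compound 1 to compound 3 (0.52 log units; beyond the scatter), both modest steps. The position is therefore not indifferent to the aryl group, since moving the chlorines between the 2,4-dichlorophenyl and the 2,6-dichlorophenyl left the two numbers within the scatter, whereas the change of ring system leaves compound 3 the weakest of the three. No measurement shown here accounts for this loss.

The change to compound 3 removes both chlorines, adds a five-membered aromatic ring with a hetero atom and brings in a hydrogen-bond donor all at once, so the compounds shown cannot say which of these differences goes with the higher number. An unsubstituted phenyl at the same place would isolate the loss of the chlorines, and a 1-methylindol-3-yl would test the indole nitrogen hydrogen while keeping the ring system.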